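Furan-2-yl for Bromo, Tried on a Second Core

The source may report more compounds than this note shows. Statements on the series, on what has been measured and on what is new or still open speak of the compounds shown alone.

Measured so far in an assay on CHO cells for displacement of a labelled ligand from transmembrane domain-containing protein TMIGD3 (Homo sapiens); a lower number here means a stronger inhibitor, a higher number a weaker inhibitor:
compound 1, `CCCn1c(Br)nc2c(N)nc(NCCCc3ccccc3)nc21`: 1950 nM
compound 2, `CCCn1c(-c2ccco2)nc2c(N)nc(NCCCc3ccccc3)nc21`: 266 nM
compound 3, `CCCn1c(Br)nc2c(NCc3ccccc3)ncnc21`: 11100 nM

Compound 2 differs from compound 1 in one place only, (furan-2-yl in place of bromo on an aromatic carbon), and that change made a 7.3-fold lower number from compound 1 to compound 2 (0.87 log units; beyond the scatter). Compound 3 and compound 1 differ in more than one place; how the two cores differ is not broken down here. Compound 3 gives the highest number of the three in this assay.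

Compound 4, `CCCn1c(-c2ccco2)nc2c(NCc3ccccc3)ncnc21`, is not yet measured. It stands to compound 3 as compound 2 stands to compound 1, through (furan-2-yl in place of bromo on an aromatic carbon), the same change at the same place. Compound 4 is expected to show a step of similar size, a 6.2-fold lower number from compound 3 to compound 4 (0.79 log units; beyond the scatter), resting on a 7.3-fold lower number from compound 1 to compound 2 (0.87 log units; beyond the scatter) and on the value of compound 3, 11100 nM. Compound 4 is estimated at 1800 nM, between 700 nM and 5000 nM.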

Compound 4, inhibition constant: 402 nM
Estimate against measurement, compound 4: 4.5-fold (0.65 log units) above; measured number outside the range, below it.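

In this assay furan-2-yl in place of bromo again lowered the number, giving a 28-fold lower number from compound 3 to compound 4 (1.44 log units; beyond the scatter) on this second core, so the direction of the change carried over. The size of the step did not carry over, since the two steps stand apart: the same change on two cores in this assay, a 7.3-fold lower number (0.87 log units; beyond the scatter) from compound 1 to compound 2 and a 28-fold lower number (1.44 log units; beyond the scatter) from compound 3 to compound 4, 3.8-fold (0.58 log units) apart, beyond the scatter of two such steps. For the compounds shown here, with only two pairs, this shows that the size of the step depends on the core, but it does not show which of the differences between the two cores sets that size, or what a third core would give.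

The compounds shown leave open whether a thiophene or phenyl ring in place of bromo would behave as furan-2-yl does. They also leave open whether the step would hold with a butyl chain in place of the propyl group.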